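Chloro in place of hydrogen on the aryl ring of compound 3

The source may hold more compounds than are shown below. What is called first, only, known or untested is meant among the compounds shown, and "the series" means these compounds.

This account concerns an ADME assay on RD cells (Homo sapiens) for cytotoxicity, read by MTT assay, with a stated time of 3 days; a higher number here means that more compound is tolerated, a lower number that less compound is tolerated. Compound 1 `CC[C@@H](CCn1cncn1)c1ccccc1` gives 91.2 ug/mL in this assay, compound 2 `CCC[C@@H](CCn1cncn1)c1ccc(Cl)cc1` gives 40.8 ug/mL, and compound 3 `CCCC[C@@H](CCn1cncn1)c1ccccc1` gives 47.5 ug/mL. Compound 3 thus holds the second highest of the three numbers, with compound 2 nearest and compound 1 furthest, both within the scatter. Among the measured compounds shown here, the one measured step with a single structural change, a 1.9-fold lower number from compound 1 to compound 3 (0.28 log units; within the scatter), concerns the saturated chain and not the aromatic ring.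

Compound 4 `CCCC[C@@H](CCn1cncn1)c1ccc(Cl)cc1` differs from compound 3 by chloro in place of hydrogen on an aromatic carbon. For the measured compounds named here, no measured step isolates this change: compound 2 carries the chloro group but also a shorter chain, and its value and that of compound 3 lie within the scatter of each other. Nothing in the data therefore points to a step beyond the scatter. Compound 4 is expected to give about 40 ug/mL, with a range from 20 ug/mL to 80 ug/mL, which would mean a step of a 1.2-fold lower number from compound 3 to compound 4 (0.07 log units; within the scatter).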

Compound 4, half-maximal cytotoxic concentration: 18.7 ug/mL
For compound 4 the middle estimate is 2.1-fold (0.33 log units) above the measured one, outside the stated range (below it).
By their numbers in this assay, from the lowest: compound 4; then compounds 2, 3 and 1 (each within the scatter of the next, the first and the last beyond it).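

In this assay, among the compounds shown here, chloro in place of hydrogen on an aromatic carbon, para to a large group, gives a 2.5-fold lower number from compound 3 to compound 4 (0.40 log units; beyond the scatter) and so is the first change on the ring that can be read on its own, a modest step that lies beyond the scatter. With the chloro group in place, the step on the saturated chain gives a 2.2-fold lower number from compound 2 to compound 4 (0.34 log units; beyond the scatter) and also passes the scatter, while the chain step without chloro, a 1.9-fold lower number from compound 1 to compound 3 (0.28 log units; within the scatter), stayed within it. The data shown offer no measured reason for either step.

The compounds shown leave open whether fluoro, methoxy or a carboxylic acid on that aromatic carbon would move the number as chloro does. They also leave open what a longer chain would do alongside the chloro group.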